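From 1-hydroxyethyl to pyrazin-2-yl on a shared core

The source may report more compounds than this note shows. Statements on the series, on what has been measured and on what is new or still open speak of the compounds shown alone.

Compound 1 `CC(O)c1nc([C@@H](O)[C@H](O)[C@H](O)CO)c[nH]1`: 10300 ng.h/mL
Compound 2 `CC(=O)N/N=C(\C)c1nc([C@@H](O)[C@H](O)[C@H](O)CO)c[nH]1`: 1030 ng.h/mL
Compound 3 `OC[C@@H](O)[C@@H](O)[C@H](O)c1c[nH]c(-c2ncn(Cc3ccccc3)n2)n1`: 587 ng.h/mL

In an ADME assay on the whole organism (plasma, strain 129/SvEvBrd x C57BL/6) for pharmacokinetics, with Mus musculus as the target, at a dose of 10 mg/kg by the oral route (a lower number here means less compound in the circulation, a higher number more compound in the circulation at the dose given), compound 1 holds the highest of the three numbers, and compound 2 and compound 3 both lie beyond the scatter below it. The step followed here leads to compound 4 `OC[C@@H](O)[C@@H](O)[C@H](O)c1c[nH]c(-c2cnccn2)n1`, which has not yet been measured. Pyrazin-2-yl stands in place of 1-hydroxyethyl on an aromatic carbon (pyrazin-2-yl in place of 1-hydroxyethyl on an aromatic carbon). Within the data shown here, no two measured compounds differ in one place only, so the size of this step in this assay can be judged only loosely. A drop beyond the scatter is expected. The closest guide is compound 3 at 587 ng.h/mL, which also carries a ring-bearing group in place of 1-hydroxyethyl, and compound 2 at 1030 ng.h/mL also sits well under compound 1. In numbers, the expected change is a 13-fold lower number from compound 1 to compound 4 (1.11 log units; beyond the scatter). The estimate for compound 4 is 800 ng.h/mL, with an expected range of 200 ng.h/mL to 3500 ng.h/mL.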

Compound 4, area under the concentration-time curve: 1250 ng.h/mL
Estimate against measurement, compound 4: 1.6-fold (0.19 log units) below, within the range that was stated.
By their numbers in this assay, from the lowest: compounds 3, 2 and 4 (each within the scatter of the next, the first and the last beyond it); then compound 1.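

Among these compounds, the change from compound 1 to compound 4 gives the first reading of a single change at this position, the aromatic carbon between two ring nitrogen atoms: in this assay there is an 8.2-fold lower number from compound 1 to compound 4 (0.92 log units; beyond the scatter). The substitution of one six-membered aromatic ring with 2 hetero atoms for the open 1-hydroxyethyl group, with no ring, therefore does not leave the number intact, so this position is not indifferent to what it carries. Nothing available explains the size of this step.

The compounds shown leave open whether the lower number goes with the departure of the hydroxyl of 1-hydroxyethyl or with the arrival of the pyrazin-2-yl ring. An ethyl group or a phenyl ring at the same place would bear on that question, and so would a 1-aminoethyl group.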